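Fourth methoxy group on a styryl sulfone scaffold

The compounds below may be only part of what the source reports. "The series", "measured", "known", "first", "only" and "open" are said of these compounds alone.

Compound 2 `COc1ccc(CS(=O)(=O)/C=C/c2ccc(OC)c(OC)c2)cc1` is the point of departure. In a functional assay on H157 cells (Homo sapiens) for antiproliferative activity, read by trypan blue exclusion (a higher number here means a weaker inhibitor, a lower number a stronger inhibitor), compound 2 gives > 20000 nM, which is a limit of the assay and not a number. Its two measured neighbours stand the same way. Compound 1 `COc1ccc(/C=C/S(=O)(=O)Cc2ccc(OC)cc2)cc1` gives > 20000 nM in this assay, a limit. Compound 3 `COc1ccc(CS(=O)(=O)/C=C/c2cc(OC)c(OC)cc2OC)cc1` gives > 20000 nM in this assay, also a limit. The step that the two limits leave unreadable from compound 1 to compound 2 is therefore unreadable, and so is a step that the two limits leave unreadable from compound 2 to compound 3, because of the limit of > 20000 nM in this assay, at which 3 of the 3 values shown sit.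

Compound 4 `COc1ccc(CS(=O)(=O)/C=C/c2cc(OC)c(OC)c(OC)c2)cc1` has not yet been measured. It differs from compound 2 by methoxy in place of hydrogen on an aromatic carbon. The two measured steps that add a methoxy group to an aromatic carbon, a step that the two limits leave unreadable from compound 1 to compound 2 and a step that the two limits leave unreadable from compound 2 to compound 3, are the ones that bear on this change, yet neither has a readable size, so no direction can be drawn from them. Every measured compound here sits at the same limit. Compound 4 is expected to behave alike, with an expected step that the limit leaves unreadable from compound 2 to compound 4 that cannot be told from the scatter. Compound 4 is expected to give 30000 nM in this assay, with a range from 10000 nM to 100000 nM, and most probably a limit will be reported once more.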

Compound 4, half-maximal inhibitory concentration: > 20000 nM
Compound 4 ended at the assay's limit (the forecaster's own chance of this, stated with the estimate: 85%); the middle value does not contradict the limit.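

Compound 4 gives > 20000 nM in this assay, which is a limit and not a number. The step from compound 2 to compound 4 therefore cannot be read, because all the compounds shown end at the same limit: the limit of > 20000 nM in this assay, at which 4 of the 4 values shown sit.

Compounds 1, 2, 3 and 4 leave open whether adding a methoxy group to an aromatic carbon changes antiproliferative activity at all.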